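Carbamoyl in place of hydrogen on compound 1

The compounds below may be only part of what the source reports. "The series", "measured", "known", "first", "only" and "open" are said of these compounds alone.

In a functional assay on the whole organism (stomach) with Rattus norvegicus as the target (on this read-out lower numbers stand for an effect already at smaller amounts and higher numbers for an effect only at larger amounts of compound), compound 1 `O=C(Nc1ccccc1)c1ccc(-c2nn[nH]n2)cc1` gives 40 mg/kg. Going by the values given here, compound 2 `O=C(Nc1ccccc1)c1cccc(-c2nn[nH]n2)c1` gives 38.1 mg/kg, within the scatter of compound 1, and the two share the high end of the numbers so far. Compound 3 `O=C(Nc1ccccc1-c1nn[nH]n1)c1ccc(-c2nn[nH]n2)cc1` gives 6.1 mg/kg, a lower number than either.

Compound 4 `NC(=O)c1ccc(NC(=O)c2ccc(-c3nn[nH]n3)cc2)cc1` differs from compound 1 by carbamoyl in place of hydrogen on an aromatic carbon, para to a large group: carbamoyl in place of hydrogen on an aromatic carbon.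

Among the compounds with values here, one measured step bears on this change: a 6.6-fold lower number from compound 1 to compound 3 (0.82 log units; beyond the scatter), a modest step beyond the scatter, with 2H-tetrazol-5-yl in place of hydrogen on an aromatic carbon. Within the data shown here, the entering group there is a different one, and no measured step carries carbamoyl. Taking the size of a 6.6-fold lower number from compound 1 to compound 3 (0.82 log units; beyond the scatter) as an upper guide, a smaller move towards lower numbers in this assay is expected. The expected step is a 2.0-fold lower number from compound 1 to compound 4 (0.30 log units; within the scatter). For compound 4 the estimate is 20 mg/kg, with an expected range from 6 mg/kg to 60 mg/kg.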

Compound 4, dose for 50% inhibition: 33 mg/kg
Compound 4: middle estimate off by 1.7-fold (0.22 log units), on the low side; low and high end bracket the measured number.
By their numbers in this assay, from the lowest: compound 3; then compounds 4, 2 and 1 (each within the scatter of the next).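

In this assay, carbamoyl in place of hydrogen on an aromatic carbon, para to a large group, leaves the number within the scatter (a 1.2-fold lower number from compound 1 to compound 4 (0.08 log units; within the scatter)). This position therefore accepts carbamoyl, a group of 3 heavy atoms, without a shift that can be told from compound 1. Among the single changes shown, 2H-tetrazol-5-yl remains the only entering group with a step beyond the scatter (a 6.6-fold lower number from compound 1 to compound 3 (0.82 log units; beyond the scatter)), and no measurement on hand accounts for the difference between the two steps.

As far as these compounds go, whether a carboxylic acid, an amine or a methyl ester at this same position would give a step beyond the scatter remains open. Also open, from the compounds shown here alone, is whether carbamoyl at this position would change the number of compound 3.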